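Three Amide Aryl Groups and a Fourth Still Unmeasured

The source may hold more compounds than are shown below. What is called first, only, known or untested is meant among the compounds shown, and "the series" means these compounds.

Compound 1 `O=C(COc1ccc2cc(/C=C3/SC(=O)NC3=O)ccc2c1)Nc1ccccc1` gives 4500 nM in an assay on isolated protein for inhibition of histone deacetylase 8 (Homo sapiens), with a stated time of 1 h; on this read-out lower numbers stand for stronger inhibition and higher numbers for weaker inhibition.
Compound 2 `Cc1cccc2sc(NC(=O)COc3ccc4cc(/C=C5/SC(=O)NC5=O)ccc4c3)nc12` gives 5800 nM in this assay.
Compound 3 `Cc1cccc(NC(=O)COc2ccc3cc(/C=C4/SC(=O)NC4=O)ccc3c2)n1` gives 7500 nM in this assay.

Compound 3 carries the highest of the three numbers, yet the steps reaching it are small: a 1.3-fold higher number from compound 2 to compound 3 (0.11 log units; within the scatter) and a 1.7-fold higher number from compound 1 to compound 3 (0.22 log units; within the scatter). Between the first two, a 1.3-fold higher number from compound 1 to compound 2 (0.11 log units; within the scatter). All three changes sit on the amide-type nitrogen, and none of them moves the number beyond the scatter.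

Compound 4 `O=C(COc1ccc2cc(/C=C3/SC(=O)NC3=O)ccc2c1)Nc1ccc(Br)c(Br)c1` differs from compound 3 at that same position: 3,4-dibromophenyl in place of 6-methylpyridin-2-yl on an amide-type nitrogen. The step to 3,4-dibromophenyl has not been measured directly, but the three measured steps all exchange one aryl group for another on this nitrogen, and each stayed within the scatter. Compound 1, whose phenyl group is the nearest relative of the incoming 3,4-dibromophenyl, gives 4500 nM, a number at the lower end of the set.

On that basis compound 4 is expected to land near the measured compounds, with a step of about a 1.5-fold lower number from compound 3 to compound 4 (0.18 log units; within the scatter), a modest shift toward a lower number that may itself fall inside the scatter. The estimate for compound 4 is 5000 nM, with a likely range from 2200 nM to 11000 nM.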

Compound 4, half-maximal inhibitory concentration: > 50000 nM
Compound 4 ended at the assay's limit; the forecaster's own chance of this, stated with the estimate: 5%; at least 10-fold (1.00 log units) between middle value and limit.
By their numbers in this assay, from the lowest: compounds 1, 2 and 3 (each within the scatter of the next). At a limit, above all of these: compound 4.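

Compound 4 stands at a limit of this assay and not at a number: the limit of > 50000 nM in this assay, at which 1 of the 4 values shown sits.

Until now, the amide-type nitrogen had taken phenyl, 4-methyl-1,3-benzothiazol-2-yl and 6-methylpyridin-2-yl with every step inside the scatter, and the position could have seemed indifferent to the aryl group it carries. The entry of 3,4-dibromophenyl ends that reading, with an at least 6.6-fold higher number from compound 3 to compound 4 (0.82 log units; beyond the scatter) and an at least 8.6-fold higher number from compound 2 to compound 4 (0.93 log units; beyond the scatter) and also an at least 11-fold higher number from compound 1 to compound 4 (1.04 log units; beyond the scatter). That last step is the most telling, since both groups are six-membered aromatic rings of carbon only and differ by the bromine atoms, which shows that this position responds to what is attached to the phenyl ring and not only to which aryl group is present.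

The compounds shown do not separate the two bromine atoms, so it stays open whether a phenyl with a single bromine would remain close to compound 1 or also reach the limit. Going by these compounds, it is equally open whether chlorine atoms, methyl groups or a carboxylic acid on the phenyl ring would be tolerated at this position.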